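The source may hold more compounds than are shown below. What is called first, only, known or untested is meant among the compounds shown, and "the series" means these compounds.

Within the data shown here, compound 1 `O=c1[nH]c(=O)n([C@H]2C[C@@H]3O[PH](O)(O)OC[C@H]3O2)cc1F` holds the only plain number in a functional assay (Raji cells) for antiproliferative activity, with Homo sapiens as the target; a higher number here means a weaker inhibitor, a lower number a stronger inhibitor: in this assay compound 1 gives 0.164 ug/mL. Among the measured compounds shown here, the other measured compound, compound 2 `O=c1[nH]c(=O)n([C@H]2C[C@@H]3OP(=O)(OCc4ccccc4)OC[C@H]3O2)cc1I`, differs from compound 1 in more than one place, so no single step between the two can be read. In this assay compound 2 gives > 100 ug/mL; 69 ug/mL (2 entries); the record is the several entries of compound 2 in this assay, > 100 ug/mL; 69 ug/mL (2 entries).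

Compound 3 `O=c1[nH]c(=O)n([C@H]2C[C@@H]3O[PH](O)(O)OC[C@H]3O2)cc1Cl` has not yet been measured in this assay. It differs from compound 1 by chloro in place of fluoro on an aromatic carbon. For the measured compounds named here, since no step between measured compounds is available, the size of this change is a matter of expectation only. Compound 3 is expected to be weaker than compound 1, by a step of a 30-fold higher number from compound 1 to compound 3 (1.48 log units; beyond the scatter) that goes beyond the usual scatter. Compound 3 is estimated at 5 ug/mL, within a range from 0.5 ug/mL to 50 ug/mL.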

Compound 3, concentration for 50% inhibition: 337 ug/mL
Estimate against measurement, compound 3: 67-fold (1.83 log units) below; measured number above the stated range.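

Swapping fluoro for chloro on an aromatic carbon, one heavy atom for one with no change in the counted hydrogen-bond donors or acceptors, gives in this assay a 2100-fold higher number from compound 1 to compound 3 (3.31 log units; beyond the scatter). Among these compounds, with the rest of the core of compound 1 unchanged, this pair shows that activity depends strongly on which of these two halogens sits at this position, something the earlier compounds could not show. Compound 2 carries iodo at the same position but differs from compound 1 in more than one place, so no step can be read, and one of its entries is a limit of the assay; its record offers only a loose parallel: the several entries of compound 2 in this assay, > 100 ug/mL; 69 ug/mL (2 entries)

The compounds shown leave open how bromo, methyl, an amine or a nitrile would behave at this position. They also leave open whether the loss seen with chloro would hold on a different core.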